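Swapping the sulfonylamino group for hydroxymethyl in compound 3

A few compounds are considered here, and "the series" means these few. Any claim that something is new, unique, unknown or untested is made for them only; others in the source may bear on it.

In a functional assay on SW-620 cells (Homo sapiens) for antiproliferative activity, read by MTT assay, with a stated time of 72 h (on this read-out lower numbers stand for stronger inhibition and higher numbers for weaker inhibition), compound 1 (`O=C1O[C@H]([C@@H](O)Cn2cc(-c3cc(F)cc(F)c3)nn2)C(OCc2ccccc2)=C1OCc1ccccc1`) reads > 100000 nM as a limit of the assay and not a number. Within the data shown here, compound 2 (`Cc1ccc(S(=O)(=O)NCc2cn(C[C@H](O)[C@H]3OC(=O)C(OCc4ccccc4)=C3OCc3ccccc3)nn2)cc1`) gives 45800 nM as the only true number so far, so it has no measured neighbour to be ranked against on a numerical scale. Compound 3 (`O=C1O[C@H]([C@@H](O)Cn2cc(CCO)nn2)C(OCc2ccccc2)=C1OCc1ccccc1`) differs from compound 2 as follows (hydroxymethyl in place of ((4-methylphenyl)sulfonyl)amino on a saturated chain carbon bound to an aromatic carbon): hydroxymethyl in place of ((4-methylphenyl)sulfonyl)amino on a saturated chain carbon bound to an aromatic carbon. Among the measured compounds shown here, one measured step bears on this (an at least 2.1-fold lower number from compound 1 to compound 2 (0.33 log units; beyond the scatter)), as it changed the same substituent and brought in the group now leaving. Its loss is therefore expected to move the number back up. The expected step is a 1.5-fold higher number from compound 2 to compound 3 (0.18 log units; within the scatter) in this assay on this single precedent. For compound 3 the estimated value is 70000 nM with an expected range from 30000 nM to 100000 nM around it.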

Compound 3, half-maximal inhibitory concentration: > 100000 nM
Compound 3: a limit, no number (the forecaster's own chance of this, stated with the estimate: 45%); middle value at least 1.4-fold (0.15 log units) from the limit.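

In this assay, the ((4-methylphenyl)sulfonyl)amino group has now been tested in both directions, and replacing it with hydroxymethyl on the saturated chain carbon gives an at least 2.1-fold higher number from compound 2 to compound 3 (0.33 log units; beyond the scatter). Compound 3 sits at a limit of the assay, not a number, so the short 2-hydroxyethyl chain does not bring back the reading that compound 2 gives, and the measurable activity among these three compounds stays with compound 2 alone. The step between compound 1 and compound 3 cannot be read, and the full size of the loss stays hidden because of the ceiling on these readings: the limit of > 100000 nM in this assay, at which 2 of the 3 values shown sit.

The compounds shown leave open whether the sulfonylamino part or the 4-methylphenyl ring carries the gain. They also leave open how an amine, a carboxylic acid or a longer chain would read at this place.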